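The source may hold more compounds than are shown below. What is called first, only, known or untested is meant among the compounds shown, and "the series" means these compounds.

Within the data shown here, compound 1 `CC(C#Cc1cccc(C(=O)NCCC(c2ccccc2)c2ccccc2)c1)N(O)C(N)=O` and compound 2 `CC(C#Cc1cccc(C(=O)NCc2ccc(F)cc2C(F)(F)F)c1)N(O)C(N)=O` share a core and are the two compounds measured so far in an assay for inhibition of Polyunsaturated fatty acid 5-lipoxygenase (Homo sapiens), read by HPLC, with stated times of 15 min and 10 min; on this read-out higher numbers stand for weaker inhibition and lower numbers for stronger inhibition. Compound 1 gives 300 nM in this assay, the lower of the two numbers, which here means the stronger inhibition. Compound 2 gives 1300 nM in this assay, a higher number that lies beyond the usual scatter of the measurement. These two compounds differ in more than one place, so their pair says nothing about any single change.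

Compound 3 `CC(C#Cc1cccc(C(=O)NCCC(c2ccccc2)c2ccc(Cl)cc2)c1)N(O)C(N)=O` has not yet been measured. It differs from compound 1 in one place only: chloro in place of hydrogen on an aromatic carbon. Among the measured compounds shown here, nothing among the measured pairs shows how this change acts, so the step is expected to be small, a 1.2-fold lower number from compound 1 to compound 3 (0.08 log units; within the scatter), and may not stand out from the scatter at all. On that basis compound 3 is estimated at 250 nM in this assay, with a likely range from 100 nM to 700 nM.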

Compound 3, half-maximal inhibitory concentration: 120 nM
For compound 3 the middle estimate is 2.1-fold (0.32 log units) above the measured one, and the stated range covers the measured number.
By their numbers in this assay, from the lowest: compound 3; then compound 1; then compound 2.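

Turning one phenyl of compound 1 into 4-chlorophenyl gives a 2.5-fold lower number from compound 1 to compound 3 (0.40 log units; beyond the scatter) in this assay, the first comparison here in which only one place changes. The aromatic carbon para to a large group can therefore carry chloro in place of hydrogen with no loss of inhibition, and here the modest step goes toward stronger inhibition. No measurement shown gives a reason for this step.

Whether this step is particular to chloro stays open, as the compounds shown include no fluoro, methyl, methoxy or carboxylic acid at this place. Also open, from the compounds shown here alone, is what a second chloro on the other phenyl would do, and whether chloro at another carbon of the same ring would give a similar step.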